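This account rests on a few compounds, and the source may have more. Where it says the series, first, only, none or still open, it means among the compounds named here.

Measured compounds: compound 1 `CC(=O)OC/C=C/c1ccc(OCc2ccccc2)c(OC(C)=O)c1` gives 38000 nM in a functional assay on PC-3 cells (Homo sapiens) for inhibition, read by MTT assay, with a stated time of 48 h; on this read-out higher numbers stand for weaker inhibition and lower numbers for stronger inhibition; compound 2 `CCC(OC(C)=O)c1ccc(O)c(OC(C)=O)c1` gives 48000 nM in this assay.

Compound 1 has the lower of the two numbers, but its gap to compound 2 lies within the scatter, so the two cannot be told apart on this read-out. Compound 3 `CC(=O)OC/C=C/c1ccc(OCc2ccccc2)c(O)c1` differs from compound 1 by hydrogen in place of acetyl on an oxygen on an aromatic ring. Going by the values given here, no measured pair shows this change. With compound 2, which also carries a free hydroxy, sitting within the scatter of compound 1, the step is expected to be a 1.1-fold higher number from compound 1 to compound 3 (0.02 log units; within the scatter), none beyond the scatter. Compound 3 is therefore estimated at 40000 nM, within 15000 nM to 100000 nM.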

Compound 3, half-maximal inhibitory concentration: 3500 nM
For compound 3 the middle estimate is 11-fold (1.06 log units) above the measured one; the whole stated range lies above it.
By their numbers in this assay, from the lowest: compound 3; then compounds 1 and 2 (each within the scatter of the next).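

Going by these compounds alone, replacing acetyl by hydrogen on this oxygen on an aromatic ring gives an 11-fold lower number from compound 1 to compound 3 (1.04 log units; beyond the scatter) in this assay, the only large step seen so far. The read-out therefore responds strongly to the group on this oxygen, which compound 1 and compound 2, differing in more than one place, could not show. Nothing available explains why the free hydroxy goes with the lower number. On these data alone, whether a methyl ether or a longer acyl group such as propionyl on this oxygen would keep that lower number remains open.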